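Swapping the pyrimidine isomer on the piperidine nitrogen

This account rests on a few compounds, and the source may have more. Where it says the series, first, only, none or still open, it means among the compounds named here.

Measured so far in an ADME assay on microsomes (Rattus norvegicus) for metabolic stability; a lower number here means that the compound disappears faster, a higher number that the compound lasts longer:
- compound 1 `CC(C)(C)C(=O)N1N=CCC1c1cccc(Cl)c1`: 0.05 h
- compound 2 `O=C(c1cn[nH]c1)N1CCC(C(=O)N2N=CCC2c2ccccc2)CC1`: > 2.75 h
- compound 3 `N#Cc1cc(N2CCC(C(=O)N3N=CC[C@H]3c3cc(F)cc(F)c3)CC2)ncn1`: 1.15 h

The value of compound 2 is a limit of the assay, not a number. Of the two plain numbers, compound 3 has the higher, and compound 1 sits far below it, well beyond the usual scatter. Compound 4 `N#Cc1nccc(N2CCC(C(=O)N3N=CC[C@H]3c3cc(F)cc(F)c3)CC2)n1` differs from compound 3 in one place: a group of 8 heavy atoms (5 carbon, 3 nitrogen; one six-membered aromatic ring with 2 hetero atoms) in place of a group of 8 heavy atoms (5 carbon, 3 nitrogen; one six-membered aromatic ring with 2 hetero atoms), on an amine nitrogen in a ring. Among the measured compounds shown here, no measured pair shows this kind of change, so the step is expected to be small, in no clear direction, and within the scatter. Compound 4 is therefore estimated at 1.2 h, ranging from 0.6 h to 2.5 h, an expected step of a 1.0-fold higher number from compound 3 to compound 4 (0.02 log units; within the scatter).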

Compound 4, half-life: 0.917 h
The estimate for compound 4 lay 1.3-fold (0.12 log units) above the measured number, within the range that was stated.
By their numbers in this assay, from the lowest: compound 1; then compounds 4 and 3 (each within the scatter of the next). At a limit, above all of these: compound 2.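

In this assay, among the compounds shown here, this is the first pair that differs only at the ring amine nitrogen: with the same atoms joined differently, the 2-cyanopyrimidin-4-yl group gives a 1.3-fold lower number from compound 3 to compound 4 (0.10 log units; within the scatter). The two isomers therefore cannot be told apart by their numbers, and the placing of the nitrile and ring nitrogens shows no measurable effect in this pair. Nothing available bears on this result.

Still open, on these data alone, is whether a pyridine ring on this nitrogen would fit the same picture. Also open, as far as these compounds go, is whether replacing the nitrile with a methoxy group or an amide would matter.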